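Urea aryl swap on a diethylaminopropyl-bearing core

This account rests on a few compounds, and the source may have more. Where it says the series, first, only, none or still open, it means among the compounds named here.

Measured compounds:
compound 1, `CN(C)CCCNc1nc(-c2ccc(NC(=O)Nc3ccccc3Cl)cc2)nc2c(Cl)c(Cl)sc12`, 490 nM in a functional assay on NCI-H460 cells (Homo sapiens) for cytotoxicity, read by MTT assay, with a stated time of 72 h; on this read-out lower numbers stand for stronger inhibition and higher numbers for weaker inhibition
compound 2, `CN(C)CCNc1nc(-c2ccc(NC(=O)Nc3ccccc3Cl)cc2)nc2c(Cl)c(Cl)sc12`, 440 nM in this assay
compound 3, `CCN(CC)CCCNc1nc(-c2ccc(NC(=O)Nc3ccc(F)cc3)cc2)nc2c(Cl)c(Cl)sc12`, 450 nM in this assay

Among the three numbers compound 3 stands second highest, with compound 2 its nearest neighbour and compound 1 its furthest; both gaps lie within the scatter, so the three compounds cannot be told apart on this assay.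

Compound 4, `CCN(CC)CCCNc1nc(-c2ccc(NC(=O)Nc3ccccc3Cl)cc2)nc2c(Cl)c(Cl)sc12`, differs from compound 3 in one place: 2-chlorophenyl in place of 4-fluorophenyl on an amide-type nitrogen. Among the measured compounds shown here, no measured step covers this change. For the measured compounds named here, the one step that exists, a 1.1-fold lower number from compound 1 to compound 2 (0.05 log units; within the scatter), concerns the chain, not the urea aryl, and is within the scatter. Compounds 1 and 2 carry the 2-chlorophenyl urea that enters here, and their numbers sit beside that of compound 3, which carries the 4-fluorophenyl that leaves; compound 1 and compound 3 differ in two places, so that comparison is loose.

On this basis compound 4 is expected to show no step beyond the scatter, no change at the digits printed from compound 3 to compound 4 (within the scatter), and is estimated at 450 nM, between 220 nM and 900 nM.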

Compound 4, half-maximal inhibitory concentration: 330 nM
Compound 4: middle estimate off by 1.4-fold (0.13 log units), on the high side; the range from low to high includes it.
By their numbers in this assay, from the lowest: compounds 4, 2, 3 and 1 (each within the scatter of the next).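

In this assay the change on the amide-type nitrogen gives a 1.4-fold lower number from compound 3 to compound 4 (0.13 log units; within the scatter) and so replaces 4-fluorophenyl with 2-chlorophenyl without a step that can be told from the scatter. With the 2-chlorophenyl urea held fixed, the chain and amine differences read the same way: a 1.3-fold lower number from compound 2 to compound 4 (0.12 log units; within the scatter) and a 1.5-fold lower number from compound 1 to compound 4 (0.17 log units; within the scatter) both stay within the scatter, so none of the changes read here separates these compounds. Nothing available accounts for this flat picture.

The swap alters the halogen and its place together, and the compounds shown do not separate the two. On these data alone, what 4-chlorophenyl or 2-fluorophenyl on that nitrogen would give stays open, as does the effect of a morpholine in place of diethylamino at the chain end.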